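From 3-chlorophenyl to 4-chlorophenyl in a weak series

The source may hold more compounds than are shown below. What is called first, only, known or untested is meant among the compounds shown, and "the series" means these compounds.

Compound 1 `C/C(=C\CC/C(C)=C/CC[C@@H]1[C@@]2(C)CCC(=O)C(C)(C)[C@H]2CC[C@@]1(C)O)CC/C=C(\C)C(=O)OCc1cn(-c2ccc(F)cc2)nn1`: > 150000 nM, a limit
Compound 2 `C/C(=C\CC/C(C)=C/CC[C@@H]1[C@@]2(C)CCC(=O)C(C)(C)[C@H]2CC[C@@]1(C)O)CC/C=C(\C)C(=O)OCc1cn(-c2ccccc2Br)nn1`: > 150000 nM, a limit
Compound 3 `C/C(=C\CC/C(C)=C/CC[C@@H]1[C@@]2(C)CCC(=O)C(C)(C)[C@H]2CC[C@@]1(C)O)CC/C=C(\C)C(=O)OCc1cn(-c2cccc(Cl)c2)nn1`: 103000 nM

These compounds share one core and differ only in the halogen-bearing phenyl group on an aromatic nitrogen. Within the data shown here, in a functional assay on DU-145 cells (Homo sapiens) for antiproliferative activity, read by MTT assay, with a stated time of 48 h (on this read-out higher numbers stand for weaker inhibition and lower numbers for stronger inhibition), compound 3 is the only one with a real number, 103000 nM. The other two stop at the limit of > 150000 nM in this assay, at which 2 of the 3 values shown sit, so neither has an exact position.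

The measured steps therefore say little. The floors of an at least 1.4-fold lower number from compound 1 to compound 3 (0.16 log units; that floor lies within the scatter) and an at least 1.4-fold lower number from compound 2 to compound 3 (0.16 log units; that floor lies within the scatter) both lie within the scatter, and a step that the two limits leave unreadable from compound 1 to compound 2 cannot be sized at all.

Compound 4 `C/C(=C\CC/C(C)=C/CC[C@@H]1[C@@]2(C)CCC(=O)C(C)(C)[C@H]2CC[C@@]1(C)O)CC/C=C(\C)C(=O)OCc1cn(-c2ccc(Cl)cc2)nn1` has the same atoms as compound 3, joined differently: 4-chlorophenyl in place of 3-chlorophenyl on an aromatic nitrogen. In words, this is 4-chlorophenyl in place of 3-chlorophenyl on an aromatic nitrogen. Among the measured compounds shown here, no measured step makes this exact move, so those floors are the only guide.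

Compound 1, the 4-fluorophenyl member, gives only the limit > 150000 nM. That hints weakly at a slightly higher number, but no step beyond the scatter is expected in this assay. The expected step is a 1.2-fold higher number from compound 3 to compound 4 (0.08 log units; within the scatter). Compound 4 is estimated at 125000 nM, with an expected range from 70000 nM to 220000 nM.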

Compound 4, half-maximal inhibitory concentration: > 150000 nM
Compound 4: no number, only a limit; the forecaster's own chance of this, stated with the estimate: 45%; middle value at least 1.2-fold (0.07 log units) from the limit.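

Replacing 3-chlorophenyl with 4-chlorophenyl keeps the same atoms and changes only where the chlorine sits on the phenyl ring, and it gives an at least 1.4-fold higher number from compound 3 to compound 4 (0.16 log units; that floor lies within the scatter) in this assay. This is the first direct comparison of two chlorine-bearing members, but compound 4 ends at a limit, so the change can be stated only as a floor and not as a true size, and a real difference between the two is neither shown nor ruled out. Steps from compound 1 and from compound 2 to compound 4 cannot be read, because both ends of each are limits, and compound 3 stays the only member with a real number: the limit of > 150000 nM in this assay, at which 3 of the 4 values shown sit.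

As far as these compounds go, all four compounds carry one halogen on the phenyl group, and whether any change at this position can bring the number down well beyond the scatter remains open. A methoxy group or an amine on the phenyl ring, or a benzyl group in place of the phenyl group, lies outside what these compounds can say.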